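The source may report more compounds than this note shows. Statements on the series, on what has been measured and on what is new or still open speak of the compounds shown alone.

Measured compounds:
compound 1, `COc1ccc(-c2cc(/C=C/C(=O)c3cc(OC)c(OC)c(OC)c3)nc3cc(-c4ccccc4)nn23)cc1OC` — 7200 nM
compound 2, `COc1cc(/C=C/C(=O)c2cc(-c3cc(OC)c(OC)c(OC)c3)n3nc(-c4ccccc4)cc3n2)cc(OC)c1OC` — 25900 nM
compound 3, `COc1cc(-c2cc(/C=C/C(=O)c3ccc(C)c(C)c3)nc3cc(-c4ccccc4)nn23)cc(OC)c1OC` — 10600 nM

In a functional assay on A549 cells (Homo sapiens) for antiproliferative activity, read by MTT assay, with a stated time of 24 h (a lower number here means a stronger inhibitor, a higher number a weaker inhibitor), compound 3 gives 10600 nM, the second highest of the three numbers. Its nearest neighbour is compound 1, which in this assay gives 7200 nM, a gap that lies within the scatter, so no order between compound 1 and compound 3 can be read from these two values. The furthest is compound 2, which in this assay gives 25900 nM, a gap beyond the scatter, so compound 3 is the stronger inhibitor of that pair.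

Compound 4, `COc1cc(-c2cc(/C=C/C(=O)c3ccc(Cl)cc3)nc3cc(-c4ccccc4)nn23)cc(OC)c1OC`, is not yet measured. It differs from compound 3 in one place: 4-chlorophenyl in place of 3,4-dimethylphenyl on a carbonyl carbon. Going by the values given here, no measured pair shows this kind of exchange, so the data give no step to lean on. Compound 4 is expected to stay close to compound 3, with the step of a 1.2-fold lower number from compound 3 to compound 4 (0.07 log units; within the scatter) expected to be small and not clearly beyond the scatter. Compound 4 is therefore estimated at 9000 nM, with a range from 3500 nM to 25000 nM.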

Compound 4, half-maximal inhibitory concentration: 15500 nM
The estimate for compound 4 lay 1.7-fold (0.24 log units) below the measured number; measured number inside the range.
By their numbers in this assay, from the lowest: compounds 1, 3, 4 and 2 (each within the scatter of the next, the first and the last beyond it).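

Going by these compounds alone, compound 4 gives the first reading of a single exchange at this place, since no earlier pair differed in only one place. In this assay, putting 4-chlorophenyl in place of 3,4-dimethylphenyl on the carbonyl carbon gives a 1.5-fold higher number from compound 3 to compound 4 (0.17 log units; within the scatter) and so establishes no order between the two compounds. The aryl group on this carbonyl can therefore carry either of these two substitution patterns with no difference that can be told from the scatter, and no independent measurement bears on this result.

From the compounds shown here alone, it remains open whether an amine or a carboxylic acid on this aryl ring would move the number beyond the scatter. Going by these compounds, it is also open whether this exchange would read the same on the core of compound 1 or compound 2.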